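From 4-methylphenyl to 4-methoxyphenyl on the shared core

The source may report more compounds than this note shows. Statements on the series, on what has been measured and on what is new or still open speak of the compounds shown alone.

In a functional assay on MiaPaCa cells (Homo sapiens) for antiproliferative activity, read by sulforhodamine B assay, with a stated time of 48 h (on this read-out lower numbers stand for stronger inhibition of growth and higher numbers for weaker inhibition of growth), compound 1 (`Cc1ccc(-c2cn(CCCN3C(=O)COc4ccccc43)nn2)cc1`) gives > 100000 nM as a limit of the assay and not as a number. Compound 2 (`COc1ccc2cc(-c3cn(CCCN4C(=O)COc5ccccc54)nn3)ccc2c1`) also gives > 100000 nM as a limit. Compound 3 (`COc1ccc(-c2cn(CCCN3C(=O)COc4ccccc43)nn2)cc1`) has methoxy in place of methyl on an aromatic carbon, para to a large group (methoxy in place of methyl on an aromatic carbon). For the measured compounds named here, no measured step is available, so the expectation rests on the limit of > 100000 nM in this assay, at which 2 of the 2 values shown sit, alone. In this assay the expected a number no higher from compound 1 to compound 3 (the limit leaves the size open) is none beyond the scatter. The estimated value for compound 3 is 100000 nM (expected range 30000 nM to 200000 nM).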

Compound 3, concentration for 50% growth inhibition: 15700 nM
Beside the measured number, compound 3's estimate is 6.4-fold (0.80 log units) above it, and the stated range ends above it.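

In this assay, methoxy in place of methyl on an aromatic carbon, para to a large group, gives an at least 6.3-fold lower number from compound 1 to compound 3 (0.80 log units; beyond the scatter). This place on the ring therefore responds to the group it carries, and a single change brings the series off the assay limit. Compound 3 alone has a number, the other values being limits: the limit of > 100000 nM in this assay, at which 2 of the 3 values shown sit.

Going by these compounds, the true size of the step stays open, since the value for compound 1 is a limit. Also open, on these data alone, is what an ethoxy group, a hydroxyl or an amine would give at this place.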